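A few compounds are considered here, and "the series" means these few. Any claim that something is new, unique, unknown or untested is made for them only; others in the source may bear on it.

In an assay on isolated protein for displacement of a labelled ligand from Gonadotropin-releasing hormone receptor (Homo sapiens) (on this read-out higher numbers stand for weaker inhibition and lower numbers for stronger inhibition), compound 2 `CCCCn1cnc(CN2CCN(c3cccc4[nH]c(-c5ccc(C(C)(C)C)cc5)nc34)CC2)c1C` gives 46 nM, the lower of the two numbers shown, while compound 1 `Cc1cc(CN2CCN(c3cccc4[nH]c(-c5ccc(C(C)(C)C)cc5)nc34)CC2)nn1C` gives 83 nM; the change a 1.8-fold lower number from compound 1 to compound 2 (0.26 log units; within the scatter) lies within the scatter. Compound 3 `CCc1nc(CN2CCN(c3cccc4[nH]c(-c5ccc(C(C)(C)C)cc5)nc34)CC2)cn1C` differs from compound 2 by 2-ethyl-1-methyl-1H-imidazol-4-yl in place of 1-butyl-5-methyl-1H-imidazol-4-yl on a saturated chain carbon bound to an amine nitrogen in a ring. Within the data shown here, the one measured step that bears on such a swap of one five-membered ring for another is a 1.8-fold lower number from compound 1 to compound 2 (0.26 log units; within the scatter), which stayed within the scatter, so the expected step in this assay is a 1.3-fold higher number from compound 2 to compound 3 (0.12 log units; within the scatter), nothing beyond the scatter. Compound 3 is therefore estimated at 60 nM in this assay, with a range from 20 nM to 180 nM.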

Compound 3, half-maximal inhibitory concentration: 18 nM
The estimate for compound 3 lay 3.3-fold (0.52 log units) above the measured number; the measured number lies below the stated range.
By their numbers in this assay, from the lowest: compound 3; then compounds 2 and 1 (each within the scatter of the next).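

At this position the group attached can move the number beyond the scatter: in this assay there is a 2.6-fold lower number from compound 2 to compound 3 (0.41 log units; beyond the scatter), even though both groups are imidazoles, so the ring type alone does not settle the result. The change from the pyrazole group also reads beyond the scatter, with a 4.6-fold lower number from compound 1 to compound 3 (0.66 log units; beyond the scatter). Nothing measured here explains either step. Compound 2 and compound 3 differ in more than one alkyl group, so which of them matters stays unsettled. On these data alone, whether a propyl chain in place of the ethyl, or an amine on that chain, would lower the number further also stays open.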